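Aryloxymethyl imidazolines at the alpha-1D receptor: step to compound 3

The compounds below may be only part of what the source reports. "The series", "measured", "known", "first", "only" and "open" are said of these compounds alone.

Measured compounds:
- compound 1, `CCN(CC)C(=O)c1ccccc1OCC1=NCCN1`: < 5020 nM
- compound 2, `c1ccc(-c2ccncn2)c(OCC2=NCCN2)c1`: < 100000 nM

In a functional assay for activation of Alpha-1D adrenergic receptor (Homo sapiens), read by calcium flux (a higher number here means that more compound is needed for the effect, a lower number that less compound is needed), compound 1 gives < 5020 nM; this is a limit of the assay, not a number. Compound 2 in this assay gives < 100000 nM; this too is a limit, not a number, so where compound 2 stands within the series cannot be fixed from the two values shown. Among the measured compounds shown here, both values are limits (the limit of < 100000 nM in this assay, at which 1 of the 2 values shown sits, (the limit of < 5020 nM in this assay, at which 1 of the 2 values shown sits)), and no step between measured compounds can be read from them.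

Compound 3, `c1ccc(-c2ccoc2)c(OCC2=NCCN2)c1`, differs from compound 2 by furan-3-yl in place of pyrimidin-4-yl on an aromatic carbon. For the measured compounds named here, with no measured step to lean on, the direction of change from compound 2 to compound 3 is open; nothing here indicates a shift beyond the scatter in either direction, and the estimate of the step is a step that the limit leaves unreadable from compound 2 to compound 3. Compound 3 is expected to give about 20000 nM in this assay, within a range from 2000 nM to 100000 nM.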

Compound 3, half-maximal effective concentration: 5.01 nM
The estimate for compound 3 lay 4000-fold (3.60 log units) above the measured number; the measured number lies below the stated range.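

No step can be read from compound 2 to compound 3, because the value for compound 2 is a limit and not a number: the limit of < 100000 nM in this assay, at which 1 of the 3 values shown sits.

The compounds shown leave open the size and direction of the change in this assay when furan-3-yl takes the place of pyrimidin-4-yl.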